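Amide substituent at the pyridine carboxamide: compound 4

The source may hold more compounds than are shown below. What is called first, only, known or untested is meant among the compounds shown, and "the series" means these compounds.

Within the data shown here, compound 2 `O=C(NC1CCCC1)c1ccc(C#Cc2ccccc2)nc1` gives 30 nM in a functional assay on BHK cells for positive allosteric modulation of metabotropic glutamate receptor 5 (Homo sapiens), read by FLIPR and calcium flux (on this read-out lower numbers stand for an effect already at smaller amounts and higher numbers for an effect only at larger amounts of compound), and stands lowest of the three numbers measured so far. Compound 1 `CC(C)CCNC(=O)c1ccc(C#Cc2ccccc2)nc1` gives 510 nM in this assay, and compound 3 `O=C(NCc1ccsc1)c1ccc(C#Cc2ccccc2)cc1` gives 1200 nM. Among the measured compounds shown here, the one single-point step so far, a 17-fold lower number from compound 1 to compound 2 (1.23 log units; beyond the scatter), shows that the group on the amide-type nitrogen moves the read-out strongly.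

Compound 4 `O=C(NCc1ccsc1)c1ccc(C#Cc2ccccc2)nc1` is reached from compound 2 by (thiophen-3-yl)methyl in place of cyclopentyl on an amide-type nitrogen. For the measured compounds named here, only the step from compound 1 to compound 2 bears directly on this position, and it was large, so a change of similar size in the opposite direction is plausible when cyclopentyl is given up. Compound 3 carries the same (thiophen-3-yl)methyl amide on a core that differs from the shared core of compounds 1, 2 and 4. The value of compound 3, 1200 nM, points the same way. A step well beyond the scatter, towards a higher number, is therefore expected; the estimated step is a 10-fold higher number from compound 2 to compound 4 (1.00 log units; beyond the scatter). For compound 4 the expected value in this assay is 300 nM, with a range from 80 nM to 1500 nM.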

Compound 4, half-maximal effective concentration: 140 nM
Beside the measured number, compound 4's estimate is 2.1-fold (0.33 log units) above it; the measured number falls inside the stated range.
By their numbers in this assay, from the lowest: compound 2; then compound 4; then compound 1; then compound 3.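

In this assay the (thiophen-3-yl)methyl group on the amide-type nitrogen gives a 4.7-fold higher number from compound 2 to compound 4 (0.67 log units; beyond the scatter) on the shared core, so this position accepts an aromatic ring carrying sulfur, while cyclopentyl keeps the lowest number. The same group gives a 3.6-fold lower number from compound 1 to compound 4 (0.56 log units; beyond the scatter) when compared with isopentyl; read at the chain carbon bound to that nitrogen, this is thiophen-3-yl in place of isobutyl. On the shared core the order is therefore cyclopentyl, then (thiophen-3-yl)methyl, then isopentyl, with each gap beyond the scatter, so the large effect seen earlier is now resolved into three distinct levels and the two ring-bearing groups both stand below the open chain. No information is available to account for these differences.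

The compounds shown do not separate the contributions of the ring's attachment through a methylene, its aromatic character and its sulfur atom; benzyl, cyclopentylmethyl and (thiophen-2-yl)methyl on the same nitrogen would address those points in turn. Also open, on these data alone, is how far the ring size can move from cyclopentyl, which cyclobutyl and cyclohexyl would show.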